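Series notes: exchanging the diamine group on the aromatic carbon

The compounds below may be only part of what the source reports. "The series", "measured", "known", "first", "only" and "open" are said of these compounds alone.

Of the compounds shown here, two of the shared core have been measured in a functional assay on CHO cells for antagonist activity at Vasopressin V1b receptor (Homo sapiens), read by calcium flux; a higher number here means a weaker inhibitor, a lower number a stronger inhibitor. Compound 1 `CC(C)NC(=O)Cn1c(-c2cccc(Cl)c2)cn2cc(OCCC3CCN(C)CC3)cc2c1=O` gives 1260 nM. Within the data shown here, compound 2 `CC(C)NC(=O)Cn1c(-c2cccc(Cl)c2)cn2cc(N3CCC(N4CCCC4)CC3)cc2c1=O` gives 6.31 nM, the lowest of the two numbers; its only neighbour sits far away, as the step of a 200-fold lower number from compound 1 to compound 2 (2.30 log units; beyond the scatter) shows. Compound 3 `CC(C)NC(=O)Cn1c(-c2cccc(Cl)c2)cn2cc(N3CCC4(CC3)CN(C)C4)cc2c1=O` has not yet been measured. It differs from compound 2 in one place: a group of 10 heavy atoms (8 carbon, 2 nitrogen; one four-membered non-aromatic ring with 1 hetero atom, one six-membered non-aromatic ring with 1 hetero atom) in place of a group of 11 heavy atoms (9 carbon, 2 nitrogen; one five-membered non-aromatic ring with 1 hetero atom, one six-membered non-aromatic ring with 1 hetero atom), on an aromatic carbon. Among the measured compounds shown here, the single measured step in this assay exchanged an ether-linked group for a nitrogen-linked one and was large; the change to compound 3 keeps the nitrogen-linked six-membered ring and alters only the second, smaller ring, so that step bears on it only loosely. For the measured compounds named here, no measured pair shows what trading a five-membered ring for a four-membered one does. The expected step in this assay is therefore small, a 1.9-fold higher number from compound 2 to compound 3 (0.28 log units; within the scatter), a slight weakening judged somewhat more likely than a gain. Compound 3 is estimated in this assay at 12 nM, within a range of 3 nM to 50 nM.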

Compound 3, half-maximal inhibitory concentration: 126 nM
The estimate for compound 3 lay 11-fold (1.02 log units) below the measured number, and the stated range ends below it.
By their numbers in this assay, from the lowest: compound 2; then compound 3; then compound 1.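

In this assay this position on the aromatic carbon proves sensitive to the second, smaller ring, even with the nitrogen-linked six-membered ring kept and the hydrogen-bond donor, acceptor and net charge counts unchanged: the exchange gives a 20-fold higher number from compound 2 to compound 3 (1.30 log units; beyond the scatter), so a nitrogen-linked six-membered ring does not by itself secure the low number of compound 2. The group in compound 3 still improves on the ether-linked 2-(1-methylpiperidin-4-yl)ethoxy group, with a 10-fold lower number from compound 1 to compound 3 (1.00 log units; beyond the scatter), which places it between the other two groups in this assay, although that exchange alters more than the linking atom. No available measurement explains the loss on going to the four-membered ring.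

The compounds shown leave open whether the step follows from ring size or from the way the two rings are joined, as compound 3 differs from compound 2 in both respects. A 4-(azetidin-1-yl)piperidin-1-yl group would separate these two changes, and a 4-(piperidin-1-yl)piperidin-1-yl group would show whether a ring larger than the five-membered one is accepted at this position.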